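Working Notes on Compound 3 and Unmeasured Compound 4

The compounds below may be only part of what the source reports. "The series", "measured", "known", "first", "only" and "open" are said of these compounds alone.

Of the compounds shown here, three of the shared core have been measured in a functional assay on cells (Homo sapiens) for cytotoxicity, read by MTT assay, with a stated time of 24 h; a lower number here means a stronger inhibitor, a higher number a weaker inhibitor. Compound 1 `CCCCCCCCCCCCCCNC(=O)[C@H](CO)/N=C/c1cccc(Cl)c1` gives 24100 nM. Compound 2 `CCCCCCCCCCCCCCNC(=O)[C@H](CO)/N=C/c1cccc(O)c1` gives 32600 nM in this assay, and a 1.4-fold higher number from compound 1 to compound 2 (0.13 log units; within the scatter). Compound 3 `CCCCCCCCCCCCCCNC(=O)[C@H](CO)/N=C/c1ccccc1C` gives 87700 nM in this assay, the highest of the three numbers: a 3.6-fold higher number from compound 1 to compound 3 (0.56 log units; beyond the scatter), and a 2.7-fold higher number from compound 2 to compound 3 (0.43 log units; beyond the scatter), so compound 3 stands beyond the scatter above both others.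

Compound 4 `CCCCCCCCCCCCCCNC(=O)[C@H](CO)NCc1ccccc1Cl` differs from compound 3 in one place: a group of 9 heavy atoms (7 carbon, 1 nitrogen, 1 chlorine; one six-membered aromatic ring of carbon only) in place of a group of 9 heavy atoms (8 carbon, 1 nitrogen; one six-membered aromatic ring of carbon only), on a saturated chain carbon bound to a carbonyl carbon and a saturated chain carbon. The change removes the double bond outside the aromatic rings and brings a chlorine onto the ring. For the measured compounds named here, none of the measured steps alters that double bond, so no step bears directly on this part of the change. Only the ring substitution has any parallel: the two steps ending at compound 3, a 3.6-fold higher number from compound 1 to compound 3 (0.56 log units; beyond the scatter) and a 2.7-fold higher number from compound 2 to compound 3 (0.43 log units; beyond the scatter), show that the 2-methylphenyl group gives the highest number, and the chloro-bearing compound 1 gives the lowest.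

On that slim basis, compound 4 is expected to give a somewhat lower number than compound 3 in this assay, with wide uncertainty. The estimate for compound 4 is 50000 nM, within a range of 15000 nM to 150000 nM. That estimate means a 1.8-fold lower number from compound 3 to compound 4 (0.24 log units; within the scatter) is expected.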

Compound 4, half-maximal inhibitory concentration: 43700 nM
Estimate against measurement, compound 4: 1.1-fold (0.06 log units) above, within the range that was stated.
By their numbers in this assay, from the lowest: compounds 1, 2, 4 and 3 (each within the scatter of the next, the first and the last beyond it).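

In this assay, for the compounds shown here, compound 4 is the first compound of the series without the double bond outside the aromatic rings, and the (2-chlorobenzyl)amino group also brings a hydrogen-bond donor to this saturated chain carbon, yet the number stays within the scatter of compound 3 (a 2.0-fold lower number from compound 3 to compound 4 (0.30 log units; within the scatter)). The same holds against the two other compounds (a 1.3-fold higher number from compound 2 to compound 4 (0.13 log units; within the scatter); a 1.8-fold higher number from compound 1 to compound 4 (0.26 log units; within the scatter)), so compound 4 lies within the scatter of all three, even though compound 1 and compound 3 lie beyond the scatter of each other. Going by these compounds alone, at this position, then, a change of linkage and ring substituent made together moves the number by no more than the scatter, although the single step cannot show what either part contributes alone.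

The compounds shown leave open how the linkage and the ring substituent act apart, which a (2-methylbenzyl)amino or (3-chlorobenzyl)amino group at this position, or a longer chain or a carboxylic acid elsewhere on the series, would begin to address. No measurement beyond these numbers speaks to why the values fall as they do.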